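The compounds below may be only part of what the source reports. "The series", "measured", "known", "first", "only" and "open" are said of these compounds alone.

Measured compounds:
Compound 1 `Cc1cc(Oc2ccc(-c3ccn(CC4CC4)c(=O)c3C#N)cc2)ccn1` — 832 nM
Compound 2 `Cc1ncccc1Oc1ccc(-c2ccn(CC3CC3)c(=O)c2C#N)cc1` — 1070 nM
Compound 3 `Cc1ccc(Oc2ccc(-c3ccn(CC4CC4)c(=O)c3C#N)cc2)c(C)n1` — 263 nM

All three were tested in a functional assay on CHO cells for positive allosteric modulation of metabotropic glutamate receptor 2 (Homo sapiens), read by scintillation counting and GTPgammaS binding, with a stated time of 30 min; a higher number here means that more compound is needed for the effect, a lower number that less compound is needed. Compound 2 gives the highest of the three numbers; the step of a 1.3-fold higher number from compound 1 to compound 2 (0.11 log units; within the scatter) lies within the scatter, whereas the steps of a 4.1-fold lower number from compound 2 to compound 3 (0.61 log units; beyond the scatter) and a 3.2-fold lower number from compound 1 to compound 3 (0.50 log units; beyond the scatter) go beyond it, so compound 3 stands apart from the other two.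

Compound 4 `Cc1ncccc1Oc1ccc(-c2ccn(CC3CC3)c(=O)c2C#N)cc1Cl` differs from compound 2 in one place: chloro in place of hydrogen on an aromatic carbon. The new group sits on an aromatic carbon of a six-membered aromatic ring of carbon only, ortho to a (2-methylpyridin-3-yl)oxy group. Within the data shown here, every measured step so far alters the pyridine ring carried by the oxygen, not the ring that receives the chloro, so none of them bears directly on this change, and the size of such a step is simply unknown from these data. The expectation is therefore a step of no clear size, a 1.2-fold lower number from compound 2 to compound 4 (0.08 log units; within the scatter). Compound 4 is estimated at 900 nM, with a range from 300 nM to 2700 nM.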

Compound 4, half-maximal effective concentration: 230 nM
Compound 4: the middle estimate sits 3.9-fold (0.59 log units) above what was measured, outside the stated range (below it).
By their numbers in this assay, from the lowest: compounds 4 and 3 (each within the scatter of the next); then compounds 1 and 2 (each within the scatter of the next).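

In this assay, chloro in place of hydrogen on an aromatic carbon, ortho to a (2-methylpyridin-3-yl)oxy group, gives a 4.7-fold lower number from compound 2 to compound 4 (0.67 log units; beyond the scatter), so less compound is needed for the effect. The earlier steps shown here changed only the pyridine ring on the oxygen, whereas this one shows that the six-membered aromatic ring of carbon only also matters: one added chlorine atom moves the number beyond the usual scatter. No measurement shown here explains this step.

From the compounds shown here alone, it remains open whether this result is particular to chloro or would also appear with fluoro, methyl or methoxy at the same position. It is also unknown whether chloro would produce a similar step when the oxygen carries the 2,6-dimethylpyridin-3-yl group of compound 3.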